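The source may report more compounds than this note shows. Statements on the series, on what has been measured and on what is new or still open speak of the compounds shown alone.

The series rests on a shared core, first seen in compound 1 `O=C(O)c1cn(Cc2ccc(Br)cc2)c2ccccc2c1=O`, which carries a bromo group and, in a functional assay, tested at 100 uM (on this read-out higher numbers stand for a stronger effect at the one concentration tested and lower numbers for a weaker effect), compound 1 gives 25.4%. Compound 2 `O=C(O)c1cn(Cc2ccc(O)cc2)c2ccccc2c1=O` replaces the bromo group with a hydroxy group, and in this assay compound 2 gives 62.7%. That single change produced a number 37.3 percentage points higher from compound 1 to compound 2 (beyond the scatter). Among the two numbers in hand, compound 2 therefore stands highest, with compound 1 the only neighbour, well apart from it.

Compound 3 `O=C(O)c1cn(Cc2ccc(O)c(O)c2)c2ccccc2c1=O` has not yet been run in this assay. It differs from compound 2 by hydroxy in place of hydrogen on an aromatic carbon. Among the compounds with values here, the only measured step in the set, a number 37.3 percentage points higher from compound 1 to compound 2 (beyond the scatter), concerns a different exchange and bears on this one just indirectly: it shows that a hydroxy group on this ring is compatible with a high read-out, not that a second hydroxy group adds to it. An expectation for compound 3 is therefore a small rise or no step beyond the scatter, put as a number 5.3 percentage points higher from compound 2 to compound 3 (within the scatter). Compound 3 is estimated at 68%, within a range from 48% to 88%.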

Compound 3, a percentage reported as activity, at one concentration (the size of the read-out at that concentration, not a potency): 87.1%
For compound 3 the middle estimate is 19.1 percentage points below the measured one; measured number inside the range.
By their numbers in this assay, from the lowest: compound 1; then compound 2; then compound 3.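

Within the data shown here, the earlier pair showed only that a hydroxy group could stand in place of bromo, whereas compound 3 shows that the read-out in this assay still responds when a second hydroxy group enters the same ring. Among these compounds, the change, on a carbon that carried hydrogen, ortho to a hydroxy group and meta to a large group, gives a number 24.4 percentage points higher from compound 2 to compound 3 (beyond the scatter), so this position is not silent and the single hydroxy group of compound 2 does not mark the top of what this ring can give. Nothing available accounts for this step, and the numbers alone cannot say whether it depends on the hydroxy group already present.

The compounds shown leave open whether a hydroxy group is specifically required at this position, or whether a methoxy group, an amine or a fluoro group there would give a similar read-out. They also leave open what the new hydroxy group would do on its own, with hydrogen in place of the hydroxy group of compound 2.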